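The source may report more compounds than this note shows. Statements on the series, on what has been measured and on what is new or still open speak of the compounds shown alone.

Compound 1 `Cc1nc(-c2ccc(Cl)cc2)c(CC(=O)O)s1`: 41000 nM
Compound 2 `O=C(O)Cc1sc(C(c2ccc(F)cc2)c2ccc(F)cc2)nc1-c1cc(F)cc(F)c1`: 340 nM
Compound 3 `O=C(O)Cc1sc(C(c2ccc(F)cc2)c2ccc(F)cc2)nc1-c1ccco1`: 140 nM

In an in vitro functional assay on HEK285-7 cells for antagonist activity at prostaglandin D2 receptor 2 (Homo sapiens), read by BRET and beta-arrestin recruitment (a lower number here means a stronger inhibitor, a higher number a weaker inhibitor), compound 3 stands lowest of the three numbers; the step of a 2.4-fold lower number from compound 2 to compound 3 (0.39 log units; beyond the scatter) separates it from compound 2, while compound 1 lies far higher. Compound 4 `COc1cc(-c2nc(C(c3ccc(F)cc3)c3ccc(F)cc3)sc2CC(=O)O)ccn1` is the next compound, with the change (2-methoxypyridin-4-yl in place of furan-2-yl on an aromatic carbon). Within the data shown here, the only measured step at this position is a 2.4-fold lower number from compound 2 to compound 3 (0.39 log units; beyond the scatter), a modest one for a swap of one aromatic group for another; no measured step shows the 2-methoxypyridin-4-yl group itself. A step of similar modest size, in either direction, is therefore expected, most likely a somewhat higher number. Compound 4 is estimated at 250 nM, within 80 nM to 800 nM, an expected step of a 1.8-fold higher number from compound 3 to compound 4 (0.25 log units; within the scatter).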

Compound 4, half-maximal inhibitory concentration: 380 nM
Compound 4: middle estimate off by 1.5-fold (0.18 log units), on the low side, and the stated range covers the measured number.
By their numbers in this assay, from the lowest: compound 3; then compounds 2 and 4 (each within the scatter of the next); then compound 1.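

Putting 2-methoxypyridin-4-yl in place of furan-2-yl gives a 2.7-fold higher number from compound 3 to compound 4 (0.43 log units; beyond the scatter) in this assay, so on this core furan-2-yl keeps the lowest number of the three groups tried at this position. Against 3,5-difluorophenyl, the same group gives a 1.1-fold higher number from compound 2 to compound 4 (0.05 log units; within the scatter), so these two six-membered aromatic rings cannot be told apart here. No measured evidence bears on why these groups compare as they do. Open questions are whether another five-membered aromatic ring, such as thiophen-2-yl, would match furan-2-yl, and how an amine or a saturated cyclohexyl ring would compare at this position.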